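The compounds below may be only part of what the source reports. "The series", "measured", "known", "first", "only" and "open" are said of these compounds alone.

Measured so far in an ADME assay on microsomes from liver (Mus musculus) for metabolic stability, read by LC-MS, with a stated time of 30 min, tested at 1 uM; a lower number here means that less of the compound is left, a higher number that more of the compound is left:
compound 1 `O=C(NCc1ccc(S(=O)(=O)c2ccccc2)cc1)c1cc2ncccc2s1`, 1.6%
compound 2 `O=C(NCc1ccc(S(=O)(=O)N2CCCCC2)cc1)c1cc2ccncc2o1`, 0.14%
compound 3 `O=C(NCc1ccc(S(=O)(=O)N2CCCCC2)cc1)c1cc2cnccc2o1`, 4.6%

Compound 1 holds the second highest of the three numbers, yet its gaps to compound 2 and to compound 3 both lie within the scatter, so the three readings cannot be told apart. Compound 4 `O=C(NCc1ccc(S(=O)(=O)c2ccccc2)cc1)c1c[nH]c2ccncc12` arises from compound 1 by a group of 9 heavy atoms (7 carbon, 2 nitrogen; one five-membered aromatic ring with 1 hetero atom, one six-membered aromatic ring with 1 hetero atom) in place of a group of 9 heavy atoms (7 carbon, 1 nitrogen, 1 sulfur; one five-membered aromatic ring with 1 hetero atom, one six-membered aromatic ring with 1 hetero atom), on a carbonyl carbon. Among the compounds with values here, the only measured step of a similar kind, a number 4.5 percentage points higher from compound 2 to compound 3 (within the scatter), also swaps one bicyclic aromatic group for another on the carbonyl carbon and stays within the scatter. On that basis no step beyond the scatter is expected in this assay, and the estimated step is a number 0.9 percentage points higher from compound 1 to compound 4 (within the scatter). Compound 4 is thus expected to give 2.5%, with a range from 0.1% to 12%.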

Compound 4, percent of the compound remaining: 45%
Compound 4: middle estimate off by 42.5 percentage points, on the low side; the measured number lies above the stated range.
By their numbers in this assay, from the lowest: compounds 2, 1 and 3 (each within the scatter of the next); then compound 4.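

The exchange gives a number 43.4 percentage points higher from compound 1 to compound 4 (beyond the scatter) in this assay and so shows that this carbonyl carbon is a place where one two-ring aromatic group in place of another can decide the result, which the earlier a number 4.5 percentage points higher from compound 2 to compound 3 (within the scatter) did not reveal. Nothing at hand accounts for the rise in this assay. The entering group lacks sulfur and brings a hydrogen-bond donor, and the compounds shown do not separate these two differences. As far as these compounds go, whether that group would hold this level with an added methyl group or amine also stays open.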